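Furan-3-yl in Place of Phenyl on the Shared Core

The compounds below may be only part of what the source reports. "The series", "measured", "known", "first", "only" and "open" are said of these compounds alone.

In an ADME assay on MDBK cells (Bos taurus) for cytotoxicity, read by MTT assay, with a stated time of 96 h (on this read-out higher numbers stand for lower toxicity in this test and lower numbers for higher toxicity in this test), compound 1 `C/C(=N\NC(N)=O)c1ccc2c(c1)nc(-c1ccccc1)n2C1CCCCC1` reads > 100000 nM, a limit of the assay and not a number. Within the data shown here, compound 2 `C/C(=N\NC(N)=S)c1ccc2c(c1)nc(-c1ccccc1)n2C1CCCCC1` gives 24000 nM, the only true number so far. Among the measured compounds shown here, the single measured step is an at least 4.1-fold lower number from compound 1 to compound 2 (0.61 log units; beyond the scatter), and it lies elsewhere in the molecule. Compound 3 `C/C(=N\NC(N)=S)c1ccc2c(c1)nc(-c1ccoc1)n2C1CCCCC1` carries furan-3-yl in place of phenyl on an aromatic carbon. For the measured compounds named here, no measured step touches this place, so for compound 3 no change beyond the scatter is expected, a 1.3-fold higher number from compound 2 to compound 3 (0.10 log units; within the scatter). In this assay compound 3 is estimated at 30000 nM, within a range of 12000 nM to 80000 nM.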

Compound 3, half-maximal cytotoxic concentration: > 100000 nM
Compound 3 ended at the assay's limit (the forecaster's own chance of this, stated with the estimate: 20%); middle value at least 3.3-fold (0.52 log units) away from the limit.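

In this assay, among these compounds, the place on the aromatic carbon between two ring nitrogen atoms proves sensitive for the first time, since furan-3-yl in place of phenyl gives a change beyond the scatter: an at least 4.1-fold higher number from compound 2 to compound 3 (0.61 log units; beyond the scatter). Compound 3 stands at a limit and not a number, so this step gives only a lower bound on the size of the change: the limit of > 100000 nM in this assay, at which 2 of the 3 values shown sit.

Going by these compounds, what remains open is whether the change is specific to furan-3-yl, or whether thiophen-3-yl, pyridin-3-yl or a plain methyl group at this place would move the read-out in the same way.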